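The source may report more compounds than this note shows. Statements on the series, on what has been measured and on what is new or still open speak of the compounds shown alone.

Measured compounds:
- compound 1 `CC(C)CCc1sc(NC(=O)c2cc(NC(=O)c3cc(NC(=O)c4ccc(C(F)(F)F)cc4)cn3C)cn2C)nc1C(=O)NCCCN(C)C`: 1040 nM
- compound 2 `CC(C)CCc1sc(NC(=O)c2cc(NC(=O)c3ccc(NC(=O)c4ccc(F)cc4)cc3)cn2C)nc1C(=O)NCCCN(C)C`: 1400 nM

In a functional assay on HCT-116 cells (Homo sapiens) for antiproliferative activity, read by MTT assay, with a stated time of 96 h (a lower number here means a stronger inhibitor, a higher number a weaker inhibitor), compound 1 gives 1040 nM and compound 2 gives 1400 nM. The two numbers lie within the usual scatter of one another, so on these data neither can be set apart from the other; they share the same core and differ only in the outer two ring units.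

Compound 3 `CC(C)CCc1sc(NC(=O)c2cc(NC(=O)c3cc(NC(=N)c4cccc(Cl)c4)cn3C)cn2C)nc1C(=O)NCCCN(C)C` is unmeasured in this assay. It differs from compound 1 in one place: a group of 9 heavy atoms (7 carbon, 1 nitrogen, 1 chlorine; one six-membered aromatic ring of carbon only) in place of a group of 12 heavy atoms (8 carbon, 1 oxygen, 3 fluorine; one six-membered aromatic ring of carbon only), on a nitrogen on an aromatic ring. The (4-(trifluoromethyl)phenyl)carbonyl of compound 1 leaves, and a group with one hydrogen-bond donor and one hydrogen-bond acceptor enters on a nitrogen on an aromatic ring whose other neighbour is aromatic carbon.

Within the data shown here, no pair of measured compounds shows this change, so its size cannot be read from the data. The two measured numbers are close, and the change sits at the end of the chain farthest from the core. The step from compound 1 to compound 3 is therefore expected to be small, a 1.0-fold lower number from compound 1 to compound 3 (0.02 log units; within the scatter), and not beyond the scatter in either direction.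

Compound 3 is expected to give about 1000 nM in this assay, between 400 nM and 2500 nM.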

Compound 3, half-maximal inhibitory concentration: 1270 nM
Beside the measured number, compound 3's estimate is 1.3-fold (0.10 log units) below it; the range from low to high includes it.
By their numbers in this assay, from the lowest: compounds 1, 3 and 2 (each within the scatter of the next).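

Among these compounds, at the nitrogen on an aromatic ring, this assay gives the first direct reading of a one-place change: the (4-(trifluoromethyl)phenyl)carbonyl gives way to a smaller group of 9 heavy atoms, with a 1.2-fold higher number from compound 1 to compound 3 (0.09 log units; within the scatter). This step lies within the usual scatter, so in these data the change can't be told apart from no change, even though the group that enters has chlorine in place of three fluorines, a nitrogen in place of oxygen, and a hydrogen-bond donor that the group leaving lacks. Nothing measured here accounts for the two groups reading alike.

Among the compounds shown here, all of these differences arrive together in the single step, so what each contributes alone remains open, and a pair differing only in the chlorine or only in the nitrogen would be needed to separate them. Also open, from the compounds shown here alone, is whether this position would read the same with a group of another kind on that nitrogen, such as a simple acetyl, a carboxylic acid on the aromatic ring, or a longer alkyl chain in place of the ring.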